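The source may report more compounds than this note shows. Statements on the series, on what has been measured and on what is new or still open speak of the compounds shown alone.

Compound 1 `C=C[C@@](C)(/C=C/c1ccc(Nc2ccccc2)cc1)CCC=C(C)C`: > 36600 nM
Compound 2 `C=C[C@@](C)(/C=C/c1ccc(Nc2ccc(OC)c(OC)c2)cc1)CCC=C(C)C`: > 36600 nM

In an ADME assay on HEK293 cells (Homo sapiens) for cytotoxicity, with a stated time of 72 h (a lower number here means that less compound is needed, a higher number that more compound is needed for the effect), compound 1 gives > 36600 nM, which is a limit and not a number. Compound 2 gives > 36600 nM, also a limit and not a number. The whole measured record is therefore (the limit of > 36600 nM in this assay, at which 2 of the 2 values shown sit), and compound 2 has no numerical value.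

Compound 3 `C=C[C@@](C)(/C=C/c1ccc(Nc2ccc(OC)c(F)c2)cc1)CCC=C(C)C` is still to be measured. Relative to compound 2, the change sits ortho to a methoxy group: fluoro in place of methoxy on an aromatic carbon.

Going by the values given here, no step between measured compounds is available, so no step size can be read from the series. No step beyond the scatter is expected in this assay, in either direction. This expectation rests on compound 2, with > 36600 nM. The expected change is a number no higher from compound 2 to compound 3 (the limit leaves the size open). For compound 3 the estimated value is 36600 nM, with an expected range of 15000 nM to 60000 nM.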

Compound 3, half-maximal effective concentration: > 36600 nM
Compound 3 ended at the assay's limit; the forecaster's own chance of this, stated with the estimate: 85%; the middle value sits exactly at the limit.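

No step from compound 1 or compound 2 to compound 3 can be read in this assay, since all three values are limits and not numbers: the limit of > 36600 nM in this assay, at which 3 of the 3 values shown sit.

The compounds shown leave open whether fluoro in place of methoxy changes the concentration needed for the effect at all.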